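Ethyl Ester to Acid on a Pyridyl Chain

A few compounds are considered here, and "the series" means these few. Any claim that something is new, unique, unknown or untested is made for them only; others in the source may bear on it.

Compound 1 `O=C(O)CCCC/C=C\c1cccnc1` gives 250 nM in an assay (Equus caballus) for inhibition of Thromboxane-A synthase (Homo sapiens), using microsomes; a higher number here means a weaker inhibitor, a lower number a stronger inhibitor. Compound 2 `CCOC(=O)CCCC/C=C(\c1ccccc1)c1cccnc1` gives 600 nM, the highest of the two numbers shown, and its nearest neighbour is compound 1. Compound 3 `O=C(O)CCCC/C=C(/c1ccccc1)c1ccccn1` reaches only the limit > 100000 nM, so no number is known for it (the limit of > 100000 nM in this assay, at which 1 of the 3 values shown sits). Compound 4 `CSC(CCC/C=C(\c1ccccc1)c1cccnc1)C(=O)O` has not been measured; it differs from compound 2 in one place (carboxy(methylsulfanyl)methyl in place of (ethoxycarbonyl)methyl on a saturated chain carbon, three bonds along the chain from a double-bonded chain carbon). Among the compounds with values here, no step between measured compounds matches this change, so the expectation is a modest step to a lower number, beyond the scatter, from compound 2 to compound 4 a 4.0-fold lower number from compound 2 to compound 4 (0.60 log units; beyond the scatter). Compound 4 is estimated at 150 nM, within a range from 40 nM to 600 nM.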

Compound 4, half-maximal inhibitory concentration: 30 nM
Compound 4: middle estimate off by 5.0-fold (0.70 log units), on the high side; the measured number lies below the stated range.
By their numbers in this assay, from the lowest: compound 4; then compound 1; then compound 2. At a limit, above all of these: compound 3.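

The change of (ethoxycarbonyl)methyl to carboxy(methylsulfanyl)methyl gives a 20-fold lower number from compound 2 to compound 4 (1.30 log units; beyond the scatter) in this assay. This is the first change in a single place among the compounds shown, and it shows that this saturated chain carbon and its surroundings strongly affect the read-out. No measurement shown here explains the size of this step.

On these data alone, the change replaces the ethyl ester with a free acid and adds methylsulfanyl together, so the share of each remains open. As far as these compounds go, how a methoxy group in place of methylsulfanyl, or an amide in place of the acid, would read also remains open.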